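Working notes: a methyl removed on the ester side chain

The source may hold more compounds than are shown below. What is called first, only, known or untested is meant among the compounds shown, and "the series" means these compounds.

Two compounds of this series carry the same core and have numbers. Compound 1 `O=C(O)[C@@H]1CCCN1C(=O)CN(c1nc(Cl)nc2[nH]cnc12)C1CC1` is the proline acid; in a functional assay on the whole organism (Tail, strain ICR) with Mus musculus as the target, in the tail flick test, with a stated time of 60 min, at a dose of 25 umol/kg by the oral route (a higher number here means a stronger effect of the compound at the dose given, a lower number a weaker effect), compound 1 gives 34.9%. Compound 2 `CC[C@H](C)[C@H](NC(=O)CN(c1nc(Cl)nc2[nH]cnc12)C1CC1)C(=O)OCc1ccccc1` is the benzyl ester of the branched amino acid; in this assay compound 2 gives 40.6%. Compound 2 has the higher of the two numbers, but its distance to compound 1 lies within the scatter, so the two cannot be told apart on these data. Going by the values given here, no single-point step between measured compounds exists, and a pattern cannot be drawn from two numbers.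

Compound 3 `CC(C)[C@H](NC(=O)CN(c1nc(Cl)nc2[nH]cnc12)C1CC1)C(=O)OCc1ccccc1` is not yet measured. Against compound 2 it shows (hydrogen in place of methyl on a saturated chain carbon, three bonds along the chain from an amide-type nitrogen and a carbonyl carbon); the same difference, cut one bond further out, reads sec-butyl to isopropyl. With nothing measured on such a change in this series, the expectation in this assay is a step of a number 2.6 percentage points lower from compound 2 to compound 3 (within the scatter) from compound 2 to compound 3, that is, none beyond the scatter. Compound 3 is therefore expected to give about 38%, estimated to fall between 24% and 52%.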

Compound 3, a percentage reported as activity, at one dose (the size of the read-out at that dose, not a potency): 55.5%
Estimate against measurement, compound 3: 17.5 percentage points below; the whole stated range lies below it.
By their numbers in this assay, from the lowest: compounds 1 and 2 (each within the scatter of the next); then compound 3.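

Sec-butyl to isopropyl is the first change in this series that can be read at a single place, and in this assay it gives a number 14.9 percentage points higher from compound 2 to compound 3 (beyond the scatter). The side chain of the benzyl ester is therefore not indifferent to this edit: hydrogen in place of methyl on a saturated chain carbon, three bonds along the chain from an amide-type nitrogen and a carbonyl carbon, moves the read-out by more than the usual scatter, although this rests on one pair of compounds and supports no trend beyond them. Nothing available on these compounds accounts for the size or direction of this step.

Still open, as far as these compounds go, is how the read-out responds to other groups at this place, such as an ethyl, a plain methyl or a longer chain like n-butyl, so it is unknown whether shortening the side chain further continues the rise or reverses it. Also open, from the compounds shown here alone, is whether the same step appears with a carboxylic acid in place of the benzyl ester, and since the read-out comes from one dose, it says nothing about potency.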